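Deprotecting the piperidine: what can the limits foretell

This account rests on a few compounds, and the source may have more. Where it says the series, first, only, none or still open, it means among the compounds named here.

Compound 1, `O=C(Nc1cc(F)cc2cccnc12)c1ncccn1`, in a functional assay on BXPC-3 cells (Homo sapiens) for inhibition, read by MTT assay, with a stated time of 72 h (on this read-out higher numbers stand for weaker inhibition and lower numbers for stronger inhibition), gives > 10000 nM, which is a limit of the assay and not a number.
Compound 2, `O=C(Nc1cc(Cl)cc2cccnc12)c1ncccn1`, in this assay gives > 10000 nM, again a limit.
Compound 3, `CC(C)(C)OC(=O)N1CCC(CCOc2cc(NC(=O)c3ncccn3)c3ncccc3c2)CC1`, in this assay gives > 10000 nM, also a limit.

All three measured compounds therefore sit at the same place: the limit of > 10000 nM in this assay, at which 3 of the 3 values shown sit. Among the measured compounds shown here, the one pair that differs in a single spot, a step that the two limits leave unreadable from compound 1 to compound 2, cannot be read, since both of its ends are limits. Compound 3 stands with the other two, not better and not worse so far as the numbers can tell.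

Compound 4, `O=C(Nc1cc(OCCC2CCNCC2)cc2cccnc12)c1ncccn1`, differs from compound 3 by hydrogen in place of tert-butoxycarbonyl on an amine nitrogen in a ring. For the measured compounds named here, no measured step resembles this change, and none of the measured compounds gives a number against which a step could be sized. Compound 4 is therefore expected to stay near the limit, with the step that the limit leaves unreadable from compound 3 to compound 4 expected to be small or unreadable. The estimate for compound 4 in this assay is 15000 nM, between 3000 nM and 60000 nM.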

Compound 4, half-maximal inhibitory concentration: > 10000 nM
Compound 4: no number, only a limit; the forecaster's own chance of this, stated with the estimate: 75%; the middle value is on the limit's open side.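

Compound 4 gives > 10000 nM, which is a limit of the assay and not a number. No step from compound 1, compound 2 or compound 3 to compound 4 can be read, since every value is a limit: the limit of > 10000 nM in this assay, at which 4 of the 4 values shown sit.

How far any of these compounds truly lies beyond that limit in this assay stays open, and so does the real size of each step.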